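Thiophene pyrazole chalcones: trimming the methoxy pattern

This account rests on a few compounds, and the source may have more. Where it says the series, first, only, none or still open, it means among the compounds named here.

Measured compounds in a functional assay on MCF7 cells (Homo sapiens) for inhibition, read by sulforhodamine B assay, with a stated time of 72 h; a lower number here means a stronger inhibitor, a higher number a weaker inhibitor:
compound 1, `O=C(/C=C/c1cn(-c2ccccc2)nc1-c1ccsc1)c1ccccc1`, compound 1 gives 1900 nM
compound 2, `COc1cc(C(=O)/C=C/c2cn(-c3ccccc3)nc2-c2ccsc2)cc(OC)c1OC`, compound 2 gives 4900 nM
compound 3, `COc1ccc(C(=O)/C=C/c2cn(-c3ccccc3)nc2-c2ccsc2)c(OC)c1OC`, compound 3 gives 7400 nM

Compound 3 shows the highest number of the three in this assay. Its number is within the scatter of compound 2, so the two cannot be ordered; against compound 1 it lies beyond the scatter, compound 1 being the clearly stronger inhibitor of that pair. Both compound 2 and compound 3 carry three methoxy groups on the aryl ketone ring, compound 1 carries none.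

Compound 4, `COc1ccc(C(=O)/C=C/c2cn(-c3ccccc3)nc2-c2ccsc2)cc1OC`, differs from compound 3 in one place: hydrogen in place of methoxy on an aromatic carbon. Within the data shown here, no measured pair isolates this change, so the expectation rests on the spread between compound 1 and the trimethoxy pair only. The step from compound 3 to compound 4 is expected to be a modest lowering of the number, a 1.9-fold lower number from compound 3 to compound 4 (0.27 log units; within the scatter), possibly not beyond the scatter. Compound 4 is estimated at 4000 nM, in the range 1500 nM to 12000 nM.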

Compound 4, half-maximal inhibitory concentration: 2800 nM
For compound 4 the middle estimate is 1.4-fold (0.15 log units) above the measured one, within the range that was stated.
By their numbers in this assay, from the lowest: compounds 1, 4, 2 and 3 (each within the scatter of the next, the first and the last beyond it).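

In this assay, among these compounds, hydrogen in place of the methoxy ortho to a large group gives a 2.6-fold lower number from compound 3 to compound 4 (0.42 log units; beyond the scatter) as the first single-place step beyond the scatter, so this position on the aryl ketone ring does register a change. The other two steps do not separate their compounds: removal of a methoxy at a different place gives a 1.8-fold lower number from compound 2 to compound 4 (0.24 log units; within the scatter) and lies within the scatter, and 3,4-dimethoxyphenyl in place of phenyl gives a 1.5-fold higher number from compound 1 to compound 4 (0.17 log units; within the scatter) and also lies within it. No measurement here accounts for the step at this position.

Going by these compounds, whether an amine, a hydroxyl or a fluorine on the same aromatic carbon would behave like hydrogen or like methoxy remains open. Also open, on these data alone, is how a single methoxy at this carbon would read on an otherwise unsubstituted phenyl ketone.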